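The source may hold more compounds than are shown below. What is called first, only, known or untested is meant among the compounds shown, and "the series" means these compounds.

Compound 3 `O=C(NCc1cc(Cl)ccc1-n1cnnn1)[C@@H]1CC=NN1C(=O)[C@H](O)C1CCCCC1` gives 63 mL.min-1.g-1 in an ADME assay on liver for metabolic stability, with Liver microsome (Homo sapiens) as the target, read by LC-MS, using microsomes (a higher number here means faster removal of the compound, a lower number slower removal), the higher of the two numbers shown. The nearest is compound 2 `O=C(NCc1cc(Cl)ccc1-n1cnnn1)[C@@H]1CC=NN1C(=O)[C@H](O)c1ccccc1F`, which gives 16 mL.min-1.g-1; the step is a 3.9-fold higher number from compound 2 to compound 3 (0.60 log units; beyond the scatter). Compound 1 `CC1(C[C@@H](O)C(=O)N2N=CC[C@H]2C(=O)NCc2cc(Cl)ccc2-n2cnnn2)CC1` gives only a limit, < 12 mL.min-1.g-1. Compound 4 `CC(C)(C)C[C@@H](O)C(=O)N1N=CC[C@H]1C(=O)NCc1cc(Cl)ccc1-n1cnnn1` carries neopentyl in place of cyclohexyl on a saturated chain carbon bound to a carbonyl carbon and an oxygen on a saturated carbon. Among the compounds with values here, the steps that bear on it both end at cyclohexyl: an at least 5.2-fold higher number from compound 1 to compound 3 (0.72 log units; beyond the scatter) and a 3.9-fold higher number from compound 2 to compound 3 (0.60 log units; beyond the scatter), each a rise in this assay. Neopentyl, with no ring, sits nearer in kind to the (1-methylcyclopropyl)methyl group of compound 1 than to cyclohexyl, so a fall from compound 3 of modest size is expected, though the limit at compound 1 leaves its floor open. Compound 4 is expected to give 25 mL.min-1.g-1, between 10 mL.min-1.g-1 and 60 mL.min-1.g-1, which means a 2.5-fold lower number from compound 3 to compound 4 (0.40 log units; beyond the scatter).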

Compound 4, intrinsic clearance in microsomes: 22 mL.min-1.g-1
For compound 4 the middle estimate is 1.1-fold (0.06 log units) above the measured one; measured number inside the range.
By their numbers in this assay, from the lowest: compounds 2 and 4 (each within the scatter of the next); then compound 3. At a limit, below all of these: compound 1.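

In this assay, neopentyl in place of cyclohexyl gives a clear drop at this position (a 2.9-fold lower number from compound 3 to compound 4 (0.46 log units; beyond the scatter)). The open neopentyl chain and the 2-fluorophenyl ring lie within the scatter of each other (a 1.4-fold higher number from compound 2 to compound 4 (0.14 log units; within the scatter)), so having a ring does not by itself set the number: among these compounds, only cyclohexyl stands apart. Compound 1 is a limit: the limit of < 12 mL.min-1.g-1 in this assay, at which 1 of the 4 values shown sits. The step from that limit (an at least 1.8-fold higher number from compound 1 to compound 4 (0.26 log units; that floor lies within the scatter)) gives only a floor that lies within the scatter, and its size cannot be read.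

Where a cyclopentyl ring or an isopropyl group would fall remains open. So does the effect of an amine at this position.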